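Taking the methyl off compound 2: working notes

The source may report more compounds than this note shows. Statements on the series, on what has been measured and on what is new or still open speak of the compounds shown alone.

Of the compounds shown here, two have been tested so far. Compound 1 (`CCCCCCCC(CCO)n1cnc2c(N)ncnc21`) gives > 50000 nM in a functional assay on HCT-116 cells (Homo sapiens) for antiproliferative activity, read by MTT assay, with a stated time of 48 h (a higher number here means a weaker inhibitor, a lower number a stronger inhibitor), and this value is a limit of the assay, not a number. Going by the values given here, compound 2 (`CCCCCCCCCC(CCO)n1cnc2c(NC)ncnc21`) gives 5410 nM in this assay and is the only compound with a true number, so there is no measured spread against which to place it.

Compound 3 (`CCCCCCCCCC(CCO)n1cnc2c(N)ncnc21`) is the next to be read. It is compound 2 with hydrogen in place of methyl on a nitrogen on an aromatic ring, which is methylamino to amino (hydrogen in place of methyl on a nitrogen on an aromatic ring). Among the compounds with values here, no measured pair isolates this change, so the expectation is loose and rests on compound 2 at 5410 nM as its only anchor.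

A modest step of a 1.7-fold higher number from compound 2 to compound 3 (0.22 log units; within the scatter) is expected in this assay, toward a weaker inhibitor, though a result within the usual scatter would be no surprise. Compound 3 is estimated at 9000 nM in this assay, with an expected range from 3000 nM to 30000 nM as the working bounds.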

Compound 3, half-maximal inhibitory concentration: 10500 nM
Compound 3: the middle estimate sits 1.2-fold (0.07 log units) below what was measured; the range from low to high includes it.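

In this assay, the methyl on the nitrogen on the aromatic ring can now be read on its own, and the result is a 1.9-fold higher number from compound 2 to compound 3 (0.29 log units; within the scatter), so methylamino and amino cannot be told apart at this position on the present data. Going by these compounds alone, the chain gives the first step beyond the scatter, an at least 4.7-fold lower number from compound 1 to compound 3 (0.67 log units; beyond the scatter), with ethyl in place of hydrogen on a saturated chain carbon, eight bonds along the chain from an aromatic nitrogen. Compound 1 gives a limit of the assay and not a number, so the size of that step is open at its upper end: the limit of > 50000 nM in this assay, at which 1 of the 3 values shown sits.

Still open is whether a dimethylamino or an ethylamino group on this nitrogen would also stay within the scatter of the amino compound, since methyl is the only substituent shown there. Also open, going by these compounds, is whether a longer chain than that of compound 3 would give a further lower number, since the chain effect rests on a single pair with the amino group held fixed.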